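The source may hold more compounds than are shown below. What is called first, only, known or untested is meant among the compounds shown, and "the series" means these compounds.

Working notes on the series, read in an ADME assay on the whole organism (strain FVB) for pharmacokinetics, with Mus musculus as the target, read by LC-MS, at a dose of 30 mg/kg by the oral route; a higher number here means more compound in the circulation at the dose given, a lower number less compound in the circulation. Compound 1 (`c1cc([C@H]2CC[C@]3(CC2)OOC2(O3)C3CC4CC(C3)CC2C4)ccc1OC1CCNCC1`) gives 810 nM and compound 2 (`N[C@H]1CC[C@@H](Oc2ccc([C@H]3CC[C@]4(CC3)OOC3(O4)C4CC5CC(C4)CC3C5)cc2)CC1`) gives 1170 nM. Compound 3 (`CC1(C)CC(O)(COc2ccc([C@H]3CC[C@]4(CC3)OOC3(O4)C4CC5CC(C4)CC3C5)cc2)CC(C)(C)N1`) gives 1000 nM and stands within the scatter of both, so the three compounds form one level.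

Compound 4 (`O[C@H]1CC[C@H](NCCCOc2ccc([C@H]3CC[C@]4(CC3)OOC3(O4)C4CC5CC(C4)CC3C5)cc2)CC1`) keeps the shared core and changes on a saturated chain carbon bound to an oxygen on an aromatic ring, with 2-((4-hydroxycyclohexyl)amino)ethyl in place of 4-hydroxy-2,2,6,6-tetramethylpiperidin-4-yl on a saturated chain carbon bound to an oxygen on an aromatic ring.

Among the compounds with values here, three measured steps bear on this change, all exchanges of the group on that oxygen: a 1.4-fold higher number from compound 1 to compound 2 (0.16 log units; within the scatter), then a 1.2-fold higher number from compound 1 to compound 3 (0.09 log units; within the scatter), and a 1.2-fold lower number from compound 2 to compound 3 (0.07 log units; within the scatter). Within the data shown here, none lies beyond the scatter, but no measured compound carries the 3-((4-hydroxycyclohexyl)amino)propyl group, so the range is kept wide. On these three compounds alone, no step beyond the scatter is expected in this assay, and the estimated step is a 1.1-fold lower number from compound 3 to compound 4 (0.05 log units; within the scatter). The estimated value for compound 4 is 900 nM, with an expected range from 380 nM to 2000 nM.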

Compound 4, maximal plasma concentration: 721 nM
For compound 4 the middle estimate is 1.2-fold (0.10 log units) above the measured one; the measured number falls inside the stated range.
By their numbers in this assay, from the lowest: compounds 4, 1, 3 and 2 (each within the scatter of the next).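

In this assay, the 3-((4-hydroxycyclohexyl)amino)propyl group on the oxygen on the aromatic ring stays level with all three earlier groups: a 1.4-fold lower number from compound 3 to compound 4 (0.14 log units; within the scatter), a 1.6-fold lower number from compound 2 to compound 4 (0.21 log units; within the scatter) and a 1.1-fold lower number from compound 1 to compound 4 (0.05 log units; within the scatter). Within the data shown here, the single level seen for compounds 1, 2 and 3 therefore extends to a group with its amine nitrogen carried on a propyl chain, so this position has now taken a chain-linked cyclohexylamine with no step beyond the scatter. Nothing at hand speaks to why the numbers stay together.

From the compounds shown here alone, whether any group on this oxygen can move the maximal plasma concentration beyond the scatter remains open. Also open, going by these compounds, is how a carboxylic acid or a methoxyethyl chain would read there in place of the amine-bearing groups.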